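The source may report more compounds than this note shows. Statements on the series, on what has been measured and on what is new or still open speak of the compounds shown alone.

Compound 1 `CC(C)(Oc1ccc(Cl)cc1)C(=O)NCCOC(=S)Nc1ccc([N+](=O)[O-])cc1Cl`: in an ADME assay on RAW264.7 cells (Mus musculus) for cytotoxicity, read by MTT assay, with a stated time of 48 h (a lower number here means a stronger inhibitor, a higher number a weaker inhibitor), compound 1 gives > 800000 nM, which is a limit of the assay and not a number.
Compound 2 `O=C(NCCOC(=S)Nc1ccccc1)c1cccnc1`: compound 2 gives > 800000 nM, again only a limit.
Compound 3 `Cc1cnc(C(=O)Oc2ccc(C(N)=S)cc2)c[n+]1[O-]`: compound 3 gives > 800000 nM, also a limit.

Within the data shown here, compound 1 thus stands at the limit of > 800000 nM in this assay, at which 3 of the 3 values shown sit, and the two other compounds sit at that same limit, so no measured step between any two compounds can be drawn in this assay. Compound 4 `CC(C)(Oc1ccc(Cl)cc1)C(=O)NCCOC(=S)Nc1ccc(F)cc1` differs from compound 1 in one place: 4-fluorophenyl in place of 2-chloro-4-nitrophenyl on an amide-type nitrogen. Among the measured compounds shown here, since every compound measured so far reaches only the limit, the step from compound 1 to compound 4 is expected to be a step that the limit leaves unreadable from compound 1 to compound 4, no change beyond the scatter. Compound 4 is therefore estimated at 1000000 nM, likely between 400000 nM and 3000000 nM, most probably reported again only as a limit.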

Compound 4, half-maximal inhibitory concentration: > 800000 nM
Compound 4: a limit, no number; the forecaster's own chance of this, stated with the estimate: 85%; the middle value does not contradict the limit.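

Among these compounds, compound 1 and compound 4 both give only a limit in this assay, and no step between them can be read. The compounds shown leave open which change of structure, if any, would bring a measurable number in this assay.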